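This account rests on a few compounds, and the source may have more. Where it says the series, first, only, none or still open, it means among the compounds named here.

Measured so far:
Compound 1: `Cc1cc(O)cc(-c2nn(CC#N)cc2-c2ccnc(-c3ccc(Oc4ccccc4)cc3)c2)c1` — 93%
Compound 2: `COc1cc(C)cc(-c2nn(CC#N)cc2-c2ccnc(-c3ccc(N(C)C)cc3)c2)c1` — 100%

In a functional assay on CCRF-CEM cells (Homo sapiens) for cytotoxicity, read by sulforhodamine B assay, with a stated time of 48 h, tested at 0.01 uM (a lower number here means a stronger effect, a higher number a weaker effect of the compound at the concentration tested), compound 1 gives 93% and compound 2 gives 100%; the two numbers lie within the usual scatter of each other, so neither can be called stronger, and both show the cells barely affected at this concentration. Compound 3, `Cc1cc(O)cc(-c2nn(CC#N)cc2-c2ccnc(-c3ccc(N(C)C)cc3)c2)c1`, has not yet been measured. It differs from compound 2 in one place: hydrogen in place of methyl on an oxygen on an aromatic ring. Among the measured compounds shown here, no measured pair shows this change directly, but compound 1, which also carries the hydroxy, gives 93%. The expected step in this assay is a number 5 percentage points lower from compound 2 to compound 3 (within the scatter), nothing beyond the scatter. Compound 3 is therefore estimated at 95%, between 82% and 104%.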

Compound 3, a percentage reported as activity, at one concentration (the size of the read-out at that concentration, not a potency): 96%
Estimate against measurement, compound 3: 1 percentage points below; the range from low to high includes it.
By their numbers in this assay, from the lowest: compounds 1, 3 and 2 (each within the scatter of the next).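

In this assay, hydrogen in place of methyl on this oxygen gives a number 4 percentage points lower from compound 2 to compound 3 (within the scatter), so methoxy to hydroxy at this position now has a direct reading and causes no change beyond the scatter. Dimethylamino in place of phenoxy gives a number 3 percentage points higher from compound 1 to compound 3 (within the scatter), so that second place also shows no step beyond the scatter at this single concentration. Nothing measured here explains either result.

Still open, as far as these compounds go, is whether a longer chain on that oxygen, or an amine in place of the hydroxy, would give a step beyond the scatter in this assay. From the compounds shown here alone, whether these steps hold at higher concentrations also remains open.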